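Swapping fluoro for trifluoromethyl on compound 3

This account rests on a few compounds, and the source may have more. Where it says the series, first, only, none or still open, it means among the compounds named here.

Measured so far in a functional assay on V79 cells (Cricetulus griseus) for cytotoxicity, read by colony formation; a higher number here means a weaker inhibitor, a lower number a stronger inhibitor:
Compound 1 `O=C(O)c1cn(C2CC2)c2c(C(F)(F)F)c(N3CCCC3)c(F)cc2c1=O` gives 280 ug/mL
Compound 2 `CC1CN(c2c(F)cc3c(=O)c(C(=O)O)cn(C4CC4)c3c2C(F)(F)F)CC(C)N1` gives > 500 ug/mL as a limit
Compound 3 `NC1CCCN(c2c(F)cc3c(=O)c(C(=O)O)cn(C4CC4)c3c2F)C1` gives 53 ug/mL

Compound 3 holds the lowest number shown. Compound 4 `NC1CCCN(c2c(F)cc3c(=O)c(C(=O)O)cn(C4CC4)c3c2C(F)(F)F)C1` differs from it in one place: trifluoromethyl in place of fluoro on an aromatic carbon, ortho to a 3-aminopiperidin-1-yl group. Going by the values given here, no measured step makes this swap. Among the compounds with values here, the only step, an at least 1.7-fold higher number from compound 1 to compound 2 (0.25 log units; that floor lies within the scatter), leaves trifluoromethyl untouched. The one hint is indirect: compound 1, with trifluoromethyl and pyrrolidin-1-yl, gives 280 ug/mL, well above compound 3. Compound 2, also with trifluoromethyl, gives > 500 ug/mL, which is a limit. A moderately higher number is therefore expected, namely a 3.0-fold higher number from compound 3 to compound 4 (0.48 log units; beyond the scatter). For compound 4 the estimate is 160 ug/mL (expected range 60 ug/mL to 450 ug/mL).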

Compound 4, half-maximal inhibitory concentration: > 500 ug/mL
Compound 4 gave a limit, no number; the forecaster's own chance of this, stated with the estimate: 10%; at least 3.1-fold (0.49 log units) between middle value and limit.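

In this assay, going by these compounds alone, trifluoromethyl in place of fluoro on this aromatic carbon, ortho to a 3-aminopiperidin-1-yl group, gives an at least 9.4-fold higher number from compound 3 to compound 4 (0.97 log units; beyond the scatter), the first direct reading of this swap. With trifluoromethyl kept, 3-aminopiperidin-1-yl in place of pyrrolidin-1-yl gives an at least 1.7-fold higher number from compound 1 to compound 4 (0.25 log units; that floor lies within the scatter), so the group carried by compound 3 does not clearly lower the number. The step between compound 2 and compound 4 cannot be read, and the true sizes of the other steps stay hidden: the limit of > 500 ug/mL in this assay, at which 2 of the 4 values shown sit.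

From the compounds shown here alone, what a methyl group or a chlorine atom on this aromatic carbon would give in this assay remains open.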